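A few compounds are considered here, and "the series" means these few. Any claim that something is new, unique, unknown or untested is made for them only; others in the source may bear on it.

Compound 1 `N#Cc1cc2cc(-c3ccccc3)n(O)c2cc1C#N` and compound 2 `Cc1ccc(-c2cc3cc(C#N)c(C#N)cc3n2O)cc1` share a core that was tested in an assay on isolated protein for inhibition of Amine oxidase [flavin-containing] B (Homo sapiens), read by fluorescence and spectrophotometry, with a stated time of 20 min; a higher number here means a weaker inhibitor, a lower number a stronger inhibitor. In this assay compound 1 gives 10300 nM, and compound 2 gives 821 nM. The change between them is methyl in place of hydrogen on an aromatic carbon, and it made a 13-fold lower number from compound 1 to compound 2 (1.10 log units; beyond the scatter).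

Compound 3 `COn1c(-c2ccccc2)c(Br)c2cc(C#N)c(C#N)cc21` carries a different core; the difference between the two cores is not broken down here. For compound 3 this assay reports only a limit, > 100000 nM, which is the limit (the limit of > 100000 nM in this assay, at which 1 of the 3 values shown sits).

Compound 4 `COn1c(-c2ccc(C)cc2)c(Br)c2cc(C#N)c(C#N)cc21` has not yet been measured. It differs from compound 3 by the same change, methyl in place of hydrogen on an aromatic carbon, at a place described in the same words. For the measured compounds named here, because compound 3 sits at the limit (the limit of > 100000 nM in this assay, at which 1 of the 3 values shown sits), a step as large as the one from compound 1 to compound 2 cannot be read from a measured number, so compound 4 is expected to reach roughly an at least 1.6-fold lower number from compound 3 to compound 4 (0.22 log units; that floor lies within the scatter). Compound 4 is estimated at 60000 nM, between 15000 nM and 200000 nM, with a fair chance that only a limit is reported.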

Compound 4, half-maximal inhibitory concentration: 7460 nM
Compound 4: middle estimate off by 8.0-fold (0.91 log units), on the high side; measured number outside the range, below it.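

In this assay, the change from phenyl to 4-methylphenyl gave an at least 13-fold lower number from compound 3 to compound 4 (1.12 log units; beyond the scatter), so the lower number seen on the core of compound 1 also appeared on the core of compound 3: the same change on two cores in this assay, a 13-fold lower number (1.10 log units; beyond the scatter) from compound 1 to compound 2 and an at least 13-fold lower number (1.12 log units; beyond the scatter) from compound 3 to compound 4; the limit leaves it open whether they differ
For compound 3 the assay reports only a limit, > 100000 nM. The step on this second core therefore has a floor and no exact size, so the two pairs show the same direction but not that the change is worth the same amount on both cores, and two pairs do not make a rule for the whole series.

The compounds shown leave open whether this lower number is tied to methyl itself or would also follow from ethyl, methoxy or chlorine at the same place on the phenyl. They also leave open what an amine or a carboxylic acid would do there, on either core.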